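Dimethylamino in place of hydroxy on a benzyl-ether purine core

The source may report more compounds than this note shows. Statements on the series, on what has been measured and on what is new or still open speak of the compounds shown alone.

Compound 1 `Oc1nc(OCc2ccccc2)c2[nH]cnc2n1` is a benzyl ether on a fused two-ring core. Within the data shown here, in an assay on HT-29 cells with Methylated-DNA--protein-cysteine methyltransferase (Homo sapiens) as the target, with a stated time of 4 h (on this read-out higher numbers stand for an effect only at larger amounts of compound and lower numbers for an effect already at smaller amounts), compound 1 gives 35 uM, the lowest of the two numbers known so far. Its nearest neighbour, compound 2 `Oc1nc(OCc2ccccc2)c2[nH]c(O)nc2n1`, carries an added hydroxy on an aromatic carbon and gives 45 uM; the step of a 1.3-fold higher number from compound 1 to compound 2 (0.11 log units; within the scatter) is within the scatter.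

Compound 3 `CN(C)c1nc(OCc2ccccc2)c2[nH]cnc2n1` has not yet been measured in this assay. It differs from compound 1 by dimethylamino in place of hydroxy on an aromatic carbon. Among the measured compounds shown here, no measured step exchanges one group for another at this place; the only known step, from compound 1 to compound 2, adds a group elsewhere and is within the scatter. For the measured compounds named here, no step therefore bears directly on the change, and no step beyond the scatter in this assay is expected in either direction. For compound 3 the estimate is 40 uM, with a range from 10 uM to 160 uM, which corresponds to a step of a 1.1-fold higher number from compound 1 to compound 3 (0.06 log units; within the scatter).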

Compound 3, concentration for half-maximal effect: 110 uM
The estimate for compound 3 lay 2.8-fold (0.44 log units) below the measured number, within the range that was stated.
By their numbers in this assay, from the lowest: compounds 1 and 2 (each within the scatter of the next); then compound 3.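

In this assay, dimethylamino in place of hydroxy on the aromatic carbon between two ring nitrogen atoms gives a 3.1-fold higher number from compound 1 to compound 3 (0.50 log units; beyond the scatter), the only step shown that lies beyond the scatter. The earlier step, a 1.3-fold higher number from compound 1 to compound 2 (0.11 log units; within the scatter), placed a hydroxy elsewhere on the core and left the number within the scatter, so this position is the one place shown where a change registers, and here the number rises. The exchange takes away the hydrogen-bond donor of hydroxy and puts 3 heavy atoms where 1 stood, but no measurement here tells what lies behind the rise.

The compounds shown leave open whether a plain amino or a methylamino group at this place would stay close to compound 1 or move as far as compound 3. They also leave open how methoxy, which has no hydrogen on the attached oxygen, would read at the same carbon.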